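The source may hold more compounds than are shown below. What is called first, only, known or untested is meant among the compounds shown, and "the series" means these compounds.

Of the compounds shown here, three from one series have been tested in a functional assay on CCRF-CEM cells (Homo sapiens); on this read-out lower numbers stand for higher toxicity in this test and higher numbers for lower toxicity in this test. Compound 1 `Cc1cn([C@@H]2O[C@H](CO[Si](C)(C)C(C)(C)C)[C@@]3(OS(=O)(=O)C=C3NCC(=O)O)[C@H]2O[Si](C)(C)C(C)(C)C)c(=O)n(C)c1=O` gives 65000 nM. Compound 2 `Cc1cn([C@@H]2O[C@H](CO[Si](C)(C)C(C)(C)C)[C@@]3(OS(=O)(=O)C=C3NCC(N)=O)[C@H]2O[Si](C)(C)C(C)(C)C)c(=O)n(C)c1=O` gives 14600 nM, and compound 3 `Cc1cn([C@@H]2O[C@H](CO[Si](C)(C)C(C)(C)C)[C@@]3(OS(=O)(=O)C=C3NC(=O)c3ccccc3)[C@H]2O[Si](C)(C)C(C)(C)C)c(=O)n(C)c1=O` gives 4910 nM. Compound 2 thus stands second highest of the three numbers: the step of a 4.5-fold lower number from compound 1 to compound 2 (0.65 log units; beyond the scatter) separates it from compound 1, and the step of a 3.0-fold lower number from compound 2 to compound 3 (0.47 log units; beyond the scatter) separates it from compound 3, while the largest step in the set is a 13-fold lower number from compound 1 to compound 3 (1.12 log units; beyond the scatter).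

Compound 4 `CCNC(=O)NC1=CS(=O)(=O)O[C@@]12[C@@H](CO[Si](C)(C)C(C)(C)C)O[C@@H](n1cc(C)c(=O)n(C)c1=O)[C@@H]2O[Si](C)(C)C(C)(C)C` has not yet been measured. It differs from compound 2 in one place: ethylcarbamoyl in place of carbamoylmethyl on an amine nitrogen. Going by the values given here, the only measured step that changes this same group is a 3.0-fold lower number from compound 2 to compound 3 (0.47 log units; beyond the scatter), where a group joined through a carbonyl also replaced the carbamoylmethyl and the number fell modestly. The ethylcarbamoyl group is likewise joined through a carbonyl, so a modest fall in this assay is expected rather than none, though the group is not benzoyl and the step may be smaller. Compound 4 is therefore expected to show a 1.8-fold lower number from compound 2 to compound 4 (0.26 log units; within the scatter), giving an estimated 8000 nM, within a range from 3000 nM to 25000 nM.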

Compound 4, half-maximal cytotoxic concentration: 4260 nM
For compound 4 the middle estimate is 1.9-fold (0.27 log units) above the measured one, within the range that was stated.
By their numbers in this assay, from the lowest: compounds 4 and 3 (each within the scatter of the next); then compound 2; then compound 1.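

In this assay, ethylcarbamoyl on the amine nitrogen gives a 3.4-fold lower number from compound 2 to compound 4 (0.53 log units; beyond the scatter) and a 15-fold lower number from compound 1 to compound 4 (1.18 log units; beyond the scatter), so a second group joined through a carbonyl now lies clearly lower than both carbamoylmethyl and carboxymethyl. With a 1.2-fold lower number from compound 3 to compound 4 (0.06 log units; within the scatter), ethylamino and phenyl on that carbonyl carbon cannot be told apart in this test, so the low number at this position does not depend on a phenyl ring. No measurement is available that explains these differences.

Still open, going by these compounds, is how much the group on that carbonyl can change: a longer chain such as butylamino, or a methyl group in its place, could stay level with compound 3 and compound 4 or move away from them. On these data alone, all four compounds also carry the same tert-butyldimethylsilyl groups, so the effect of a free hydroxy group in their place remains unknown.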